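Methylating the Ring Amine of Compound 2

The compounds below may be only part of what the source reports. "The series", "measured", "known", "first", "only" and "open" are said of these compounds alone.

Compound 1 `Clc1ccc2c(C3CCCNC3)c[nH]c2n1`: 2950 nM
Compound 2 `c1cnc2[nH]c(C[C@H]3CCCN3)cc2c1`: 125 nM
Compound 3 `c1cnc2[nH]c(C[C@@H]3CCCN3)cc2c1`: 2750 nM

In an assay on membranes from brain for displacement of a labelled ligand from Neuronal acetylcholine receptor; alpha4/beta2 (Rattus norvegicus) (on this read-out higher numbers stand for weaker inhibition and lower numbers for stronger inhibition), compound 2 gives the lowest number of the three and is thus the most potent, with compounds 1 and 3 both well beyond the scatter above it. For the measured compounds named here, the only step measured between close neighbours is a 22-fold higher number from compound 2 to compound 3 (1.34 log units; beyond the scatter), which rests on (the fact that compounds 2 and 3 differ only in the configuration as drawn). Compound 4 `CN1CCC[C@@H]1Cc1cc2cccnc2[nH]1` differs from compound 2 by methyl in place of hydrogen on an amine nitrogen in a ring. Going by the values given here, no measured step alters that nitrogen, so the stereo step gives only indirect guidance: it shows that the ring carrying the amine is sensitive to change. Compound 4 is therefore expected to show a moderate weakening, a 2.8-fold higher number from compound 2 to compound 4 (0.45 log units; beyond the scatter), in this assay. The estimated value of compound 4 is 350 nM, with a range from 90 nM to 1400 nM.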

Compound 4, inhibition constant: 2510 nM
Estimate against measurement, compound 4: 7.2-fold (0.86 log units) below; the measured number lies above the stated range.
By their numbers in this assay, from the lowest: compound 2; then compounds 4, 3 and 1 (each within the scatter of the next).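

In this assay, this amine nitrogen in a ring turns out not to be a free place for substitution: methyl in place of hydrogen gives a 20-fold higher number from compound 2 to compound 4 (1.30 log units; beyond the scatter) and so removes most of the advantage of compound 2. The stereo step had shown only that configuration at the ring carbon matters, whereas this step shows that a single added carbon on the nitrogen matters too. Nothing available explains why this methyl has so large an effect.

Going by these compounds, whether ethyl on this nitrogen would behave like methyl remains open. So does whether methyl would have the same effect in compound 3, with its opposite configuration.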